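Urea aryl group: isoquinoline attachment point in the series

A few compounds are considered here, and "the series" means these few. Any claim that something is new, unique, unknown or untested is made for them only; others in the source may bear on it.

Measured compounds:
compound 1 `CN(C)C1(Cc2ccccc2)CCN(c2cc(C(F)(F)F)ccc2CNC(=O)Nc2cccc3[nH]c(=O)ccc23)CC1` — 1.67 nM
compound 2 `CN(C)C1(Cc2ccccc2)CCN(c2cc(C(F)(F)F)ccc2CNC(=O)Nc2cccc3ccncc23)CC1` — 12.3 nM

In an assay on CHO cells for displacement of a labelled ligand from transient receptor potential cation channel subfamily V member 1 (Homo sapiens), read by scintillation counting, with a stated time of 60 min (a lower number here means a stronger inhibitor, a higher number a weaker inhibitor), compound 2 gives 12.3 nM, the highest of the two numbers. Compound 1 gives 1.67 nM in this assay. Going by the values given here, the single measured step, a 7.4-fold higher number from compound 1 to compound 2 (0.87 log units; beyond the scatter), replaces the bicyclic urea substituent as a whole and is the only comparison available.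

Compound 3 `CN(C)C1(Cc2ccccc2)CCN(c2cc(C(F)(F)F)ccc2CNC(=O)Nc2cccc3cnccc23)CC1` differs from compound 2 by isoquinolin-5-yl in place of isoquinolin-8-yl on an amide-type nitrogen. Among the compounds with values here, no measured step compares two attachment points of the same isoquinoline, so the step from compound 1 to compound 2 does not bear directly on this change; it only shows that the urea aryl group matters in this assay. With nothing to support a direction, the expectation is a step within the scatter, a 1.0-fold lower number from compound 2 to compound 3 (0.01 log units; within the scatter), around the value of compound 2, with a wide range to cover the lack of a relevant comparison. Compound 3 is therefore estimated at 12 nM, expected between 3 nM and 50 nM.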

Compound 3, inhibition constant: 0.67 nM
For compound 3 the middle estimate is 18-fold (1.25 log units) above the measured one, and the stated range ends above it.
By their numbers in this assay, from the lowest: compound 3; then compound 1; then compound 2.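

In this assay, moving the attachment point alone, with the same atoms in the group, gives an 18-fold lower number from compound 2 to compound 3 (1.26 log units; beyond the scatter). This separates the attachment point of the isoquinoline from the replacement of the whole bicyclic group, which the earlier pair could not do, and shows that isoquinolin-5-yl and isoquinolin-8-yl are far from interchangeable on the amide-type nitrogen of the urea. The comparison with the earlier lead gives a 2.5-fold lower number from compound 1 to compound 3 (0.40 log units; beyond the scatter), so the group of compound 1 is not needed for a low number in this series, although no measurement available here explains either step.

Going by these compounds, it remains open whether isoquinolin-6-yl, isoquinolin-7-yl or quinolin-5-yl would match isoquinolin-5-yl. Also open, on these data alone, is how a chlorine or a methyl on the isoquinolin-5-yl group would affect the number.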